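The compounds below may be only part of what the source reports. "The series", "measured", "known", "first", "only" and "open" are said of these compounds alone.

Measured compounds:
Compound 1, `ClCc1ccc(Cn2cnc3c(Cl)ncnc32)cc1`, gives > 100000 nM in a functional assay on SK-MEL-28 cells (Homo sapiens) for cytotoxicity, read by sulforhodamine B assay, with a stated time of 48 h; a higher number here means that more compound is tolerated, a lower number that less compound is tolerated; this value is a limit of the assay, not a number.
Compound 2, `ClCc1cccc(Cn2cnc3c(Cl)nc(Cl)nc32)c1`, gives > 100000 nM in this assay; this value too is a limit of the assay.

Compound 1 thus stands at the limit of > 100000 nM in this assay, at which 2 of the 2 values shown sit, so no measured value separates it from anything else in this set, and nothing of order can be read between compound 1 and compound 2.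

Compound 3, `ClCc1ccc(Cn2cnc3c(Cl)nc(Cl)nc32)cc1`, differs from compound 1 by chloro in place of hydrogen on an aromatic carbon. No measured step of this kind exists among the compounds shown, so the expectation rests on the shared core and the limits alone. The step from compound 1 to compound 3 is expected as a number no higher from compound 1 to compound 3 (the limit leaves the size open), that is, nothing beyond the scatter. Compound 3 is therefore estimated at 100000 nM, within a range from 30000 nM to 300000 nM, and is expected most often to be reported again only as a limit.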

Compound 3, concentration lethal to 50% of the cells: 46800 nM
For compound 3 the middle estimate is 2.1-fold (0.33 log units) above the measured one; measured number inside the range.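

Chloro in place of hydrogen on the aromatic carbon between two ring nitrogen atoms is the first change here to yield a measured number in this assay, and the step reads an at least 2.1-fold lower number from compound 1 to compound 3 (0.32 log units; beyond the scatter). This shows that the position is one where a change can register in the read-out, with less compound tolerated once chloro stands there. As far as these compounds go, the true size of the step stays open, as the value for compound 1 is only a limit: the limit of > 100000 nM in this assay, at which 2 of the 3 values shown sit.

Compound 2 carries the same chloro, yet its > 100000 nM is a limit of the assay, so whether the effect of chloro depends on where the chloromethyl group sits remains unsettled. From the compounds shown here alone, whether an amine or a methoxy group at this position would move the number as chloro does also stays open.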